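The compounds below may be only part of what the source reports. "The series", "measured", "known", "first", "only" and "open" are said of these compounds alone.

Working notes on the series. Among the compounds with values here, compound 1 `CCCNC(=O)c1cc(Oc2ccc(NC(=O)c3nn(-c4ccc(C)cc4)c(=O)cc3C)cc2F)ccn1` and compound 2 `CCNC(=O)c1cc(Oc2ccc(NC(=O)c3nn(-c4ccc(C)cc4)c(=O)cc3C)cc2)ccn1` share a core and differ from each other in more than one place, so no single step is counted between them. In a functional assay on HeLa cells (Homo sapiens) for antiproliferative activity, read by MTT assay, with a stated time of 72 h (on this read-out lower numbers stand for stronger inhibition and higher numbers for weaker inhibition), compound 1 gives 14200 nM and compound 2 gives 10700 nM; the two numbers lie within the scatter of each other, so compound 1 stands level with compound 2 and nothing separates them on the numbers shown. Compound 3 `CCCNC(=O)c1cc(Oc2ccc(NC(=O)c3nn(-c4cccc(C(F)(F)F)c4)c(=O)cc3C)cc2F)ccn1` has not been measured. It differs from compound 1 in one place: 3-(trifluoromethyl)phenyl in place of 4-methylphenyl on an aromatic nitrogen. Within the data shown here, no measured step of this kind exists in the set, so the data give no direction for this change. The expectation for compound 3 is a step of a 1.2-fold lower number from compound 1 to compound 3 (0.07 log units; within the scatter), that is, no movement beyond the scatter. For compound 3 in this assay the estimate is 12000 nM, with a range from 4000 nM to 40000 nM.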

Compound 3, half-maximal inhibitory concentration: 8000 nM
For compound 3 the middle estimate is 1.5-fold (0.18 log units) above the measured one, and the stated range covers the measured number.
By their numbers in this assay, from the lowest: compounds 3, 2 and 1 (each within the scatter of the next).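

Within the data shown here, this is the first step read at this position, the aromatic nitrogen of the shared core: in this assay, 3-(trifluoromethyl)phenyl in place of 4-methylphenyl gives a step within the scatter (a 1.8-fold lower number from compound 1 to compound 3 (0.25 log units; within the scatter)) and no more. The entering group has 10 heavy atoms against 7 for the leaving group, yet on this one pair the two groups cannot be told apart in this read-out. No accompanying measurement bears on this result. Going by these compounds, whether a cyclohexyl ring or a butyl chain on that nitrogen, or a phenyl carrying a carboxylic acid or an amine, would move the number beyond the scatter stays open. Also open, on these data alone, is whether the same exchange reads alike with a butyl chain on the amide.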